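Swapping the aryl group on the piperazine: effect on rat clearance

A few compounds are considered here, and "the series" means these few. Any claim that something is new, unique, unknown or untested is made for them only; others in the source may bear on it.

Measured so far:
- compound 1, `O=C1CCc2cc(NC(=O)C(=O)N3CCN(c4ccc(Cl)cc4)CC3)ccc2N1`: "not determined" (no result reported)
- compound 2, `O=C(Nc1ccc2[nH]c(=O)oc2c1)C(=O)N1CCN(c2ccc(F)cc2)CC1`: 11.1 mL/min/kg

The study measured how fast rats remove each compound from the blood, using an ADME assay on the whole organism (Rattus norvegicus, strain Sprague-Dawley) for pharmacokinetics, using cassette dosing, at a dose of 0.5 mg/kg by the intravenous route; on this read-out lower numbers stand for slow clearance and higher numbers for fast clearance. Compound 1 has a structure on record, but for compound 1 this assay reports "not determined" (no result reported). Going by the values given here, compound 2 is therefore the only compound with a value: in this assay compound 2 gives 11.1 mL/min/kg, a moderate clearance, and there is no second measured compound to set it against, so no step between measured compounds can be drawn.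

Compound 3, `COc1ccc(N2CCN(C(=O)C(=O)Nc3ccc4[nH]c(=O)oc4c3)CC2)cc1F`, differs from compound 2 in one spot: 3-fluoro-4-methoxyphenyl in place of 4-fluorophenyl on an amine nitrogen in a ring.

Among the compounds with values here, with a single measured value and no measured step, there is no trend to lean on. The change is small, and the expectation is a step no larger than the usual scatter, leaning slightly toward faster clearance. The expected step is a 1.4-fold higher number from compound 2 to compound 3 (0.16 log units; within the scatter). For compound 3 the estimate in this assay is 16 mL/min/kg, with a likely range from 7 mL/min/kg to 35 mL/min/kg.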

Compound 3, clearance: 101 mL/min/kg
Compound 3: middle estimate off by 6.3-fold (0.80 log units), on the low side; measured number above the stated range.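

In this assay, placing 3-fluoro-4-methoxyphenyl where 4-fluorophenyl stood on an amine nitrogen in a ring gives a 9.1-fold higher number from compound 2 to compound 3 (0.96 log units; beyond the scatter), so this position is far from silent for how quickly rats clear the compound. Both groups are built on one six-membered aromatic ring of carbon only, which means that in this pair a change limited to what that ring carries is enough to shift clearance strongly. No measurement shown here accounts for the size of this rise.

Compound 3 differs from compound 2 by both a methoxy group and a moved fluorine, so this single step cannot show which of the two goes with the faster clearance. Going by these compounds alone, a plain 4-methoxyphenyl group or a 3-fluorophenyl group at the same place would carry only one part of the change, and how either would behave in this assay remains open.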